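Cyanoaziridine ureas: aryl-substituent swap at the para position

The source may report more compounds than this note shows. Statements on the series, on what has been measured and on what is new or still open speak of the compounds shown alone.

Measured so far:
compound 1, `CCOC(=O)c1ccc(NC(=O)N2CC2C#N)cc1`, 3000 nM
compound 2, `N#CC1CN1C(=O)Nc1ccc(Cl)cc1Cl`, 9400 nM
compound 3, `CCCCNC(=O)N1CC1C#N`, 17000 nM

In a functional assay on RPMI-8226 cells (Homo sapiens) for inhibition (on this read-out higher numbers stand for weaker inhibition and lower numbers for stronger inhibition), compound 1 gives the lowest of the three numbers. Compound 2 sits above it by a margin beyond the usual scatter, and compound 3, carrying a butyl chain instead of an aryl group on the urea nitrogen, sits furthest away, also beyond the scatter. On these three values compound 1 is therefore the strongest inhibitor of the set.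

Compound 4, `N#CC1CN1C(=O)Nc1ccc([N+](=O)[O-])cc1`, has not been measured. It differs from compound 1 in one place: nitro in place of ethoxycarbonyl on an aromatic carbon. The group that leaves and the group that enters each carry the same count of hydrogen-bond acceptors and no donors, and the substituent stays on the aromatic carbon para to a group of 8 heavy atoms.

Among the compounds with values here, no pair of measured compounds that differ in a single place is available, so there is no measured step to anchor the size of this change. The expectation for compound 4 is a step within the scatter, or at most a small one, in either direction. The value of compound 4 in this assay is estimated at 3500 nM, with a range from 1200 nM to 10000 nM, corresponding to an expected step of a 1.2-fold higher number from compound 1 to compound 4 (0.07 log units; within the scatter).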

Compound 4, half-maximal inhibitory concentration: 8600 nM
Estimate against measurement, compound 4: 2.5-fold (0.39 log units) below, and the stated range covers the measured number.
By their numbers in this assay, from the lowest: compound 1; then compounds 4, 2 and 3 (each within the scatter of the next).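

In this assay, within the data shown here, nitro in place of ethoxycarbonyl gives a 2.9-fold higher number from compound 1 to compound 4 (0.46 log units; beyond the scatter), the first measured single-place step, and it shows that the value responds to the group on this aromatic carbon. The two groups match in hydrogen-bond donors and acceptors, so those counts alone do not set the value here; they differ in heavy atoms and in the atoms themselves. No measurement on these compounds bears on the cause of the step.

The compounds shown leave open whether the higher number goes with the smaller group or with the loss of the ester itself. A methyl ester, a carboxylic acid or an amine on the same aromatic carbon would bear on that question.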